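Acyl chain extension on the cyclic sulfone core

The source may report more compounds than this note shows. Statements on the series, on what has been measured and on what is new or still open speak of the compounds shown alone.

Measured compounds:
compound 1 `CCCOCC1=CS(=O)(=O)c2ccccc2C1=O` — 99.9%
compound 2 `COCCOCC1=CS(=O)(=O)c2ccccc2C1=O` — 98.2%
compound 3 `O=COCC1=CS(=O)(=O)c2ccccc2C1=O` — 91.6%

All three numbers come from a functional assay on the whole organism for inhibition, with Mus musculus as the target, at a dose of 10 mg/kg; on this read-out lower numbers stand for less inhibition and higher numbers for more inhibition at the one dose given (going by the name of the read-out). Compound 3 has the lowest of the three numbers, but the gaps a number 8.3 percentage points lower from compound 1 to compound 3 (within the scatter) and a number 6.6 percentage points lower from compound 2 to compound 3 (within the scatter), like a number 1.7 percentage points lower from compound 1 to compound 2 (within the scatter), sit within the scatter, so the three cannot be ordered. Compound 4 `CCC(=O)OCC1=CS(=O)(=O)c2ccccc2C1=O` is not yet measured; it differs from compound 3 by ethyl in place of hydrogen on a carbonyl carbon, formyloxy becoming propanoyloxy. Among the compounds with values here, the steps that bear on this change are those at the oxygen on a saturated carbon, from compound 1 and from compound 2 to compound 3, both within the scatter. The step expected is therefore a number 2.4 percentage points higher from compound 3 to compound 4 (within the scatter), none beyond the scatter. Compound 4 is expected to give 94%, in the range 84% to 100%.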

Compound 4, a percentage reported as inhibition, in the whole organism at one dose (the size of the read-out at that dose, not a potency): 99.5%
Compound 4: middle estimate off by 5.5 percentage points, on the low side, and the stated range covers the measured number.
By their numbers in this assay, from the lowest: compounds 3, 2, 4 and 1 (each within the scatter of the next).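

Ethyl in place of hydrogen on a carbonyl carbon gives a number 7.9 percentage points higher from compound 3 to compound 4 (within the scatter) in this assay, so formyloxy and propanoyloxy cannot be told apart at this position. Propanoyl in place of 2-methoxyethyl gives a number 1.3 percentage points higher from compound 2 to compound 4 (within the scatter) and propanoyl in place of propyl gives a number 0.4 percentage points lower from compound 1 to compound 4 (within the scatter) on the same oxygen, so propanoyl cannot be told apart from either chain. Whether a benzoyl group or a chain carrying an amine on this oxygen would move the number beyond the scatter stays open, as does any separation of these compounds at a lower dose. Within the data shown here, no evidence on these compounds bears on this result.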